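The source may hold more compounds than are shown below. What is called first, only, known or untested is meant among the compounds shown, and "the series" means these compounds.

Compound 2 `O=c1[nH]c(=O)n([C@H]2C[C@@H]3O[PH](O)(O)OC[C@H]3O2)cc1F` gives 19 ug/mL in a functional assay on Raji cells (Homo sapiens) for antiproliferative activity (on this read-out lower numbers stand for stronger inhibition and higher numbers for weaker inhibition), the lowest of the two numbers shown; compound 3 `O=c1[nH]c(=O)n([C@H]2C[C@H](O)[C@@H](COP(=O)(O)O)O2)cc1C(F)(F)F` gives 212 ug/mL in this assay. Compound 1 `O=c1[nH]c(=O)n([C@H]2C[C@H](O)[C@@H](COP(=O)(O)O)O2)cc1Br` sits at the limit of this assay, > 1000 ug/mL, which is a limit and not a number. Compound 4 `O=c1[nH]c(=O)n([C@H]2C[C@@H]3O[PH](O)(O)OC[C@H]3O2)cc1Br` is not yet measured; it differs from compound 2 in one place: bromo in place of fluoro on an aromatic carbon. Among the measured compounds shown here, the only measured step that bears on this change sets bromo against trifluoromethyl, an at least 4.7-fold lower number from compound 1 to compound 3 (0.67 log units; beyond the scatter), with bromo on the weaker side; since one value there is a limit (the limit of > 1000 ug/mL in this assay, at which 1 of the 3 values shown sits), the full size of that step is unknown. A step towards weaker inhibition is therefore expected, a 16-fold higher number from compound 2 to compound 4 (1.20 log units; beyond the scatter). Compound 4 is expected to give 300 ug/mL, within 50 ug/mL to 1000 ug/mL.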

Compound 4, concentration for 50% inhibition: > 1000 ug/mL
Compound 4 gave a limit, no number; the forecaster's own chance of this, stated with the estimate: 30%; middle value at least 3.3-fold (0.52 log units) from the limit.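

On the core of compound 2, the change from fluoro to bromo on the aromatic carbon gives, in this assay, an at least 52-fold higher number from compound 2 to compound 4 (1.72 log units; beyond the scatter). Bromo now stands on the weaker side in both steps shown, the other being an at least 4.7-fold lower number from compound 1 to compound 3 (0.67 log units; beyond the scatter). The value of compound 4 is a limit, so the full size of the new step is unknown: the limit of > 1000 ug/mL in this assay, at which 2 of the 4 values shown sit.

Open, on these data alone, is how chloro, methyl or an amine at this place would read on the core of compound 2. Also open, as far as these compounds go, is how fluoro would read on the core of compound 1.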